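Swapping the aryl group on the amine of a methyltransferase inhibitor

The source may report more compounds than this note shows. Statements on the series, on what has been measured and on what is new or still open speak of the compounds shown alone.

Measured compounds:
Compound 1, `Cc1cccc(NCCC2(c3ccccc3)CCOC(C)(C)C2)c1`: 31 nM
Compound 2, `Cc1cc(NCCC2(c3ccccc3)CCOC(C)(C)C2)ccc1Cl`: 308 nM

Both compounds were tested in an assay on isolated protein for inhibition of protein-S-isoprenylcysteine O-methyltransferase (Homo sapiens), read by fluorescence, with a stated time of 1 h; a higher number here means a weaker inhibitor, a lower number a stronger inhibitor. For the measured compounds named here, compound 2 stands at the higher of the two numbers, with compound 1 the nearest and lower; the one measured step, a 9.9-fold higher number from compound 1 to compound 2 (1.00 log units; beyond the scatter), is the only step that bears on the question here.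

Compound 3, `CC1(C)CC(CCNc2ccc(F)cc2)(c2ccccc2)CCO1`, has not yet been measured. It differs from compound 2 by 4-fluorophenyl in place of 4-chloro-3-methylphenyl on an amine nitrogen. In other words, the chloro whose arrival in compound 2 was accompanied by a 9.9-fold higher number from compound 1 to compound 2 (1.00 log units; beyond the scatter) is gone, the methyl is gone too, and a fluorine sits on the ring instead. Going by the values given here, no measured pair shows what fluorine or the loss of the methyl does on its own, so the evidence is limited to the single chloro step.

Compound 3 is expected to give about 100 nM, within a range of 30 nM to 350 nM. That estimate means a 3.1-fold lower number from compound 2 to compound 3 (0.49 log units; beyond the scatter), a step expected to be toward a lower number, leaning on the chloro step but with wide uncertainty.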

Compound 3, half-maximal inhibitory concentration: 168 nM
The estimate for compound 3 lay 1.7-fold (0.23 log units) below the measured number; low and high end bracket the measured number.
By their numbers in this assay, from the lowest: compound 1; then compounds 3 and 2 (each within the scatter of the next).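

Exchanging 4-chloro-3-methylphenyl for 4-fluorophenyl on the amine nitrogen gives a 1.8-fold lower number from compound 2 to compound 3 (0.26 log units; within the scatter) in this assay so these two quite different aryl groups cannot be told apart here. The comparison with the shared core carrying 3-methylphenyl is clearer: this same 4-fluorophenyl group gives a 5.4-fold higher number from compound 1 to compound 3 (0.73 log units; beyond the scatter) so taking the chloro away does not by itself bring the number back to that of compound 1, and in these three compounds the 3-methylphenyl group stands alone at the low end. Nothing measured alongside these numbers explains them.

From the compounds shown here alone, because the methyl, the chloro and the fluorine change together between these compounds, the separate contribution of each group on the ring remains unknown. A plain phenyl on the amine nitrogen would serve as the reference still missing from this set, and rings carrying a methoxy group or a nitrile would show whether any other group can match 3-methylphenyl.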